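A few compounds are considered here, and "the series" means these few. Any claim that something is new, unique, unknown or untested is made for them only; others in the source may bear on it.

Notes on the series. Compound 1 `Cc1cccc(N(C)CC2CCC/C(=C\c3ccccc3)C2=O)c1` is the reference; in a functional assay on the whole organism (Ear, strain Kunming) for inhibition, with Mus musculus as the target, with stated times of 1 h and 30 min, at a dose of 200 mg/kg by the oral route (a higher number here means more inhibition at the dose given (going by the name of the read-out), a lower number less inhibition), compound 1 gives 44.9%. Compound 2 `Cc1ccc(/C=C2\CCCC(CN(C)c3cccc(C)c3)C2=O)cc1` carries the change (methyl in place of hydrogen on an aromatic carbon), and in this assay compound 2 gives 35.4%; the step of a number 9.5 percentage points lower from compound 1 to compound 2 (within the scatter) is within the scatter, so the two values are taken as indistinguishable. Compound 3 `COc1ccc(C2(O)/C(=C/c3ccc(C)cc3)CCCC2CN(C)c2ccccc2)cc1` has a different core; how that core differs from the core of compound 1 is not broken down here. In this assay compound 3 gives 16.3%, the lowest of the three values, and its gap to compound 2 as well as to compound 1 lies beyond the scatter.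

Compound 4 `COc1ccc(C2(O)/C(=C/c3ccc(C)cc3)CCCC2CN(C)c2ccc(C)cc2)cc1` has not yet been measured. It differs from compound 3 by methyl in place of hydrogen on an aromatic carbon, the same change already made from compound 1 to compound 2, at the same place on the ring, so the step from compound 3 to compound 4 in this assay is expected to resemble the earlier step. Going by the values given here, on that basis the step of a number 4.3 percentage points lower from compound 3 to compound 4 (within the scatter) is expected to stay within the scatter, leaning slightly downward, because the one measured instance of this change gave a number 9.5 percentage points lower from compound 1 to compound 2 (within the scatter). Compound 4 is thus estimated at 12% in this assay. For compound 4 the lower end of the expected range is 3%. For compound 4 the upper end of the expected range is 24%.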

Compound 4, a percentage reported as inhibition, in the whole organism at one dose (the size of the read-out at that dose, not a potency): 29.9%
For compound 4 the middle estimate is 17.9 percentage points below the measured one; the measured number lies above the stated range.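

In this assay, methyl in place of hydrogen on the core of compound 3, which turns methyl(phenyl)amino into methyl(4-methylphenyl)amino, gives a number 13.6 percentage points higher from compound 3 to compound 4 (beyond the scatter). The change therefore does not carry over unchanged from the core of compound 1 to the core of compound 3 in this read-out: the same change on two cores in this assay, a number 9.5 percentage points lower (within the scatter) from compound 1 to compound 2 and a number 13.6 percentage points higher (beyond the scatter) from compound 3 to compound 4, 23.1 percentage points apart, beyond the scatter of two such steps. This rests on a single pair for each core, and the earlier step lies within the scatter, so it shows neither a rule for either core nor a true drop on the core of compound 1, and it cannot say whether the core itself or some other difference between the two pairs accounts for the gap.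

The compounds shown leave open whether a chlorine, a methoxy group or a longer chain such as ethyl, in place of the new methyl of compound 4, would also raise the inhibition on this core. They also leave open which part of the core of compound 3, the hydroxyl or the 4-methoxyphenyl group, separates its response to the change from that of the core of compound 1.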